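Alkoxy to chloromethylphenyl swap on the anilide end

This account rests on a few compounds, and the source may have more. Where it says the series, first, only, none or still open, it means among the compounds named here.

Measured so far:
compound 1 `CC(C)COc1ccc(NC(=O)CCCCCCCSc2nnc(Cc3nn(C)c(=O)c4ccccc34)n2C)cc1` — 55000 nM
compound 2 `CC(C)Oc1ccc(NC(=O)CCCCCCCSc2nnc(Cc3nn(C)c(=O)c4ccccc34)n2C)cc1` — 93000 nM
compound 3 `COc1ccc(NC(=O)CCCCCCCSc2nnc(Cc3nn(C)c(=O)c4ccccc34)n2C)cc1` — 201000 nM

In an assay on cells for inhibition of IL15-IL15 receptor (Homo sapiens), read by AlphaScreen, with stated times of 30 min and 1 h (on this read-out higher numbers stand for weaker inhibition and lower numbers for stronger inhibition), compound 1 gives the lowest number of the three, though the step of a 1.7-fold higher number from compound 1 to compound 2 (0.23 log units; within the scatter) lies within the scatter, so no order between those two is claimed. Shrinking the alkyl on the aromatic oxygen weakened inhibition modestly: a 3.7-fold higher number from compound 1 to compound 3 (0.56 log units; beyond the scatter) and a 2.2-fold higher number from compound 2 to compound 3 (0.33 log units; beyond the scatter).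

Compound 4 `Cc1ccc(NC(=O)CCCCCCCSc2nnc(Cc3nn(C)c(=O)c4ccccc34)n2C)c(Cl)c1` changes the anilide end: 2-chloro-4-methylphenyl in place of 4-(isobutoxy)phenyl on an amide-type nitrogen. Going by the values given here, none of the measured steps covers this swap; they only bear on it by showing that less alkyl on that oxygen gave higher numbers. Removing the alkoxy altogether is therefore expected to give a weaker, modestly higher number in this assay, estimated as a 2.4-fold higher number from compound 1 to compound 4 (0.37 log units; beyond the scatter). For compound 4 the expected value is 130000 nM, in the range 45000 nM to 400000 nM.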

Compound 4, half-maximal inhibitory concentration: 76000 nM
Beside the measured number, compound 4's estimate is 1.7-fold (0.23 log units) above it; the measured number falls inside the stated range.
By their numbers in this assay, from the lowest: compounds 1, 4 and 2 (each within the scatter of the next); then compound 3.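

In this assay, an alkoxy group on the anilide end proves not to be required: 2-chloro-4-methylphenyl on the amide-type nitrogen, which has no oxygen, cannot be told apart from 4-(isobutoxy)phenyl (a 1.4-fold higher number from compound 1 to compound 4 (0.14 log units; within the scatter)) or 4-isopropoxyphenyl (a 1.2-fold lower number from compound 2 to compound 4 (0.09 log units; within the scatter)). Against 4-methoxyphenyl, the same swap gives a modestly lower number (a 2.6-fold lower number from compound 3 to compound 4 (0.42 log units; beyond the scatter)). No supporting data explain this result.

On these data alone, the separate contributions of the chlorine and the methyl remain open. So does how a carboxylic acid or dimethylamino group would read on this aromatic ring.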